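Ring substituent swaps on the hydrazone end of the series

The source may report more compounds than this note shows. Statements on the series, on what has been measured and on what is new or still open speak of the compounds shown alone.

Three compounds share one core and differ only on the aromatic ring bound to the hydrazone carbon. In a functional assay on MCF7 cells (Homo sapiens) for cytotoxicity, read by MTT assay, with a stated time of 48 h (a lower number here means a stronger inhibitor, a higher number a weaker inhibitor), compound 1 `O=C(CSc1nnc(-c2ccncc2)o1)N/N=C/c1ccccc1` gives 14600 nM, compound 2 `COc1ccc(/C=N/NC(=O)CSc2nnc(-c3ccncc3)o2)cc1` gives 17600 nM, and compound 3 `O=C(CSc1nnc(-c2ccncc2)o1)N/N=C/c1ccccc1F` gives 21800 nM. Compound 3 carries the largest number of the three, yet both gaps, a 1.5-fold higher number from compound 1 to compound 3 (0.17 log units; within the scatter) and a 1.2-fold higher number from compound 2 to compound 3 (0.09 log units; within the scatter), stay within the scatter. Compound 4 `O=C(CSc1nnc(-c2ccncc2)o1)N/N=C/c1ccccc1O` is the next member: hydroxy in place of fluoro on an aromatic carbon. For the measured compounds named here, no measured step exchanges fluoro for hydroxy; the steps that bear on this ring, a 1.2-fold higher number from compound 1 to compound 2 (0.08 log units; within the scatter) and a 1.5-fold higher number from compound 1 to compound 3 (0.17 log units; within the scatter), were both within the scatter, so no shift beyond the scatter is expected, a 1.2-fold lower number from compound 3 to compound 4 (0.08 log units; within the scatter). Compound 4 is therefore estimated at 18000 nM, between 8000 nM and 40000 nM.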

Compound 4, half-maximal inhibitory concentration: 4750 nM
Compound 4: middle estimate off by 3.8-fold (0.58 log units), on the high side; measured number below the stated range.
By their numbers in this assay, from the lowest: compound 4; then compounds 1, 2 and 3 (each within the scatter of the next).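

In this assay, this ring first responds to a substituent change, with hydroxy in place of fluoro giving a 4.6-fold lower number from compound 3 to compound 4 (0.66 log units; beyond the scatter). Compound 4 also separates from the other two, with a 3.1-fold lower number from compound 1 to compound 4 (0.49 log units; beyond the scatter) and a 3.7-fold lower number from compound 2 to compound 4 (0.57 log units; beyond the scatter), whereas the hydrogen, fluoro and 4-methoxy compounds stay within the scatter of one another. No supporting data explain this shift.

Open, going by these compounds, is whether 2-aminophenyl or 2-carboxyphenyl would match 2-hydroxyphenyl. Also open, on these data alone, is whether hydroxy at another ring position would give a similar number.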